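Cyano removal on the pendant aryl of the shared core

The source may report more compounds than this note shows. Statements on the series, on what has been measured and on what is new or still open speak of the compounds shown alone.

Working notes on the series. Compound 1 `N#Cc1ccc(-c2cnc3[nH]cc(-c4nnc(-c5ccc(F)cc5)o4)c(=O)c3c2)cc1` and compound 2 `N#Cc1ccc(-c2cnc3[nH]cc(-c4nnc(-c5ccc(Cl)cc5)o4)c(=O)c3c2)cc1` share one core and differ only in the halogen on the aryl attached to the five-membered ring. In a functional assay on HCT-116 cells (Homo sapiens) for inhibition, read by MTT assay, with a stated time of 24 h, tested at 2.5 uM (a lower number here means less inhibition of growth, a higher number more inhibition of growth at the concentration tested), compound 1 gives 10.2% and compound 2 gives 13.7%; the step of a number 3.5 percentage points higher from compound 1 to compound 2 (within the scatter) leaves the two within the scatter of each other, so compound 2 stands alongside compound 1 rather than apart from it. Compound 3 `O=c1c(-c2nnc(-c3ccc(Cl)cc3)o2)c[nH]c2ncc(-c3ccccc3)cc12` is not yet measured; it differs from compound 2 by hydrogen in place of cyano on an aromatic carbon. No measured step touches this position: the single step shown concerns the halogen on the other aryl and was itself within the scatter. Nothing here therefore argues for a shift in this assay beyond the scatter, and the expectation for compound 3 rests on compound 2 alone. The estimated step of a number 1.7 percentage points lower from compound 2 to compound 3 (within the scatter) is expected to be negligible. For compound 3 the expected value is 12%, with a range from 2% to 25%.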

Compound 3, percent growth inhibition at one concentration: 9.81%
Compound 3: the middle estimate sits 2.2 percentage points above what was measured, and the stated range covers the measured number.
By their numbers in this assay, from the lowest: compounds 3, 1 and 2 (each within the scatter of the next).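

In this assay, going by these compounds alone, going from 4-cyanophenyl to phenyl gives a number 3.9 percentage points lower from compound 2 to compound 3 (within the scatter), the first reading at this position, since the earlier step concerned only the halogen on the other aryl. With the chlorophenyl part of compound 2 kept, the nitrile is therefore not needed to keep growth inhibition within the scatter of compound 2 at the concentration tested, and hydrogen in its place serves as well in this assay. No measurement bears on why this position tolerates the change, and no explanation can be offered from the data shown.

Going by these compounds, it remains open whether an amine, a carboxylic acid or a longer chain at this position would move the number beyond the scatter. On these data alone, the reading also comes from the chloro background alone, so whether the same change behaves alike with the fluoro aryl of compound 1 is still unknown.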